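The source may hold more compounds than are shown below. What is called first, only, known or untested is meant among the compounds shown, and "the series" means these compounds.

Of the compounds shown here, two that share the same core have so far been tested in an ADME assay on MRC5 cells (Homo sapiens) for inhibition, with a stated time of 72 h; on this read-out higher numbers stand for an effect only at larger amounts of compound and lower numbers for an effect already at smaller amounts. Among the measured compounds shown here, compound 1 `CO[C@H]1CC[C@H](NC(=O)c2n[nH]cc2NC(=O)c2c(C)nc3ccccn23)CC1` is the one with a measured number: in this assay compound 1 shows 34000 nM. Compound 2 `COc1cccc(OC)c1C(=O)Nc1c[nH]nc1C(=O)NCc1ccccn1` did not produce a number. For compound 2 the assay reports only a limit, > 50000 nM, so its true value is not known; this is the limit of > 50000 nM in this assay, at which 1 of the 2 values shown sits. Compound 3 `COCCNC(=O)c1n[nH]cc1NC(=O)c1c(OC)cccc1OC` has not yet been tested. It differs from compound 2 in one place: methoxymethyl in place of pyridin-2-yl on a saturated chain carbon bound to an amide-type nitrogen. For the measured compounds named here, compound 1, the only compound with a number, sits at a high concentration, and compound 2 lies beyond the reach of the assay, so nothing seen so far suggests that the change in compound 3 would bring an effect at smaller amounts of compound. The step from compound 2 to compound 3 is therefore expected to stay within the usual scatter: a step that the limit leaves unreadable from compound 2 to compound 3. Compound 3 is accordingly estimated at 60000 nM, with a range from 25000 nM to 150000 nM, and the result is most likely to come back once more as a limit rather than a number.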

Compound 3, half-maximal effective concentration: > 50000 nM
Compound 3 ended at the assay's limit (the forecaster's own chance of this, stated with the estimate: 75%); the middle value lies beyond the limit too.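

No size can be read for the change from compound 2 to compound 3, as both results in this assay are limits rather than numbers: the limit of > 50000 nM in this assay, at which 2 of the 3 values shown sit. The compounds shown leave open where the true values of compound 2 and compound 3 lie, and whether methoxymethyl in place of pyridin-2-yl changes the effect at all.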